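This account rests on a few compounds, and the source may have more. Where it says the series, first, only, none or still open, it means among the compounds named here.

Measured so far, in an assay for inhibition of serine/threonine-protein kinase Sgk1 (Homo sapiens), with stated times of 30 min and 60 min, in the presence of a further agent that is not named here; on this read-out lower numbers stand for stronger inhibition and higher numbers for weaker inhibition:
compound 1 `CN1CCC(NC(=O)c2cc(-c3ccc(NS(=O)(=O)c4cccc(Cl)c4Cl)cc3)nc3[nH]ncc23)C1`, compound 1 gives 21 nM
compound 2 `O=C(NC1CCN(C2CC2)C1)c1cc(-c2ccc(NS(=O)(=O)c3cccc(Cl)c3Cl)cc2)nc2[nH]ncc12`, compound 2 gives 610 nM
compound 3 `O=C(NC1CCN(CC2CC2)C1)c1cc(-c2ccc(NS(=O)(=O)c3cccc(Cl)c3Cl)cc2)nc2[nH]ncc12`, compound 3 gives 35 nM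

Compound 3 has the second highest of the three numbers: it sits close to compound 1, a 1.7-fold higher number from compound 1 to compound 3 (0.22 log units; within the scatter), and far from compound 2, a 17-fold lower number from compound 2 to compound 3 (1.24 log units; beyond the scatter). All three share one core and differ only in the group carried on the pyrrolidine nitrogen; changing that group alone moved the numbers by a 29-fold higher number from compound 1 to compound 2 (1.46 log units; beyond the scatter) and a 17-fold lower number from compound 2 to compound 3 (1.24 log units; beyond the scatter).

Compound 4 `NC(=O)c1cc(-c2ccc(NS(=O)(=O)c3cccc(Cl)c3Cl)cc2)nc2[nH]ncc12` is not yet measured. Its change from compound 3 is hydrogen in place of 1-(cyclopropylmethyl)pyrrolidin-3-yl on an amide-type nitrogen, so the whole ring-bearing group on the amide is removed. Among the compounds with values here, no measured step makes this kind of removal; the steps seen only alter what hangs on the ring that is now gone. That those steps were large suggests the region is sensitive, and losing all of it is a bigger change than any measured, so a large step toward a higher number is expected in this assay.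

Compound 4 is expected to give 2000 nM, within 300 nM to 15000 nM, meaning an estimated step of a 57-fold higher number from compound 3 to compound 4 (1.76 log units; beyond the scatter).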

Compound 4, half-maximal inhibitory concentration: 236 nM
The estimate for compound 4 lay 8.5-fold (0.93 log units) above the measured number; measured number outside the range, below it.
By their numbers in this assay, from the lowest: compounds 1 and 3 (each within the scatter of the next); then compound 4; then compound 2.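

The shared core keeps measurable inhibition without the whole group on the amide-type nitrogen: in this assay, replacing that group with hydrogen gives a 6.7-fold higher number from compound 3 to compound 4 (0.83 log units; beyond the scatter) and an 11-fold higher number from compound 1 to compound 4 (1.05 log units; beyond the scatter) when the starting group carries cyclopropylmethyl or methyl. The same replacement gives a 2.6-fold lower number from compound 2 to compound 4 (0.41 log units; beyond the scatter) as well, so 1-cyclopropylpyrrolidin-3-yl does worse on this read-out than plain hydrogen, while the other two ring-bearing groups do better, and a group at this position can therefore push the number either way. Nothing measured here explains these differences.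

The compounds shown leave open whether the pyrrolidine ring itself matters or whether a simple open-chain amine, such as a 2-(dimethylamino)ethyl group, would serve as well. They also leave open how a pyrrolidin-3-yl group with only hydrogen on its ring nitrogen would compare.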